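This account rests on a few compounds, and the source may have more. Where it says the series, first, only, none or still open, it means among the compounds named here.

Working notes on the bis-benzimidazole series in a functional assay on HepG2 cells (Homo sapiens) for cytotoxicity, read by MTT assay, with a stated time of 48 h; on this read-out lower numbers stand for stronger inhibition and higher numbers for weaker inhibition. Compound 1 `FC(F)(F)c1ccc2nc(-c3cccc(-c4nc5ccc(C(F)(F)F)cc5[nH]4)c3)[nH]c2c1` gives 6600 nM in this assay. Compound 2 `COc1cc(-c2nc3ccc(C(F)(F)F)cc3[nH]2)cc(-c2nc3ccc(C(F)(F)F)cc3[nH]2)c1` gives 10700 nM in this assay. Within the data shown here, the only measured step is a 1.6-fold higher number from compound 1 to compound 2 (0.21 log units; within the scatter); on the two numbers so far, compound 2 carries the highest value, with compound 1 nearest to it, and the gap between the two lies within the scatter, so no order between them is claimed.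

Compound 3 `O=[N+]([O-])c1cc(-c2nc3ccc(C(F)(F)F)cc3[nH]2)cc(-c2nc3ccc(C(F)(F)F)cc3[nH]2)c1` differs from compound 2 by nitro in place of methoxy on an aromatic carbon. Among the measured compounds shown here, no measured pair exchanges a nitro group for a methoxy group, so the only step that bears on this change is the one that alters the same group on compound 2, namely a 1.6-fold higher number from compound 1 to compound 2 (0.21 log units; within the scatter), and that step stayed within the scatter. With nothing else to go on, the step in this assay is expected to be small and its direction undetermined; the expected step is a 1.1-fold lower number from compound 2 to compound 3 (0.05 log units; within the scatter). Compound 3 is therefore estimated to give 9500 nM in this assay, with a range from 3000 nM to 30000 nM.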

Compound 3, half-maximal inhibitory concentration: 4100 nM
For compound 3 the middle estimate is 2.3-fold (0.36 log units) above the measured one, and the stated range covers the measured number.
By their numbers in this assay, from the lowest: compounds 3, 1 and 2 (each within the scatter of the next, the first and the last beyond it).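

In this assay, the place on the six-membered aromatic ring of carbon only, meta to two large groups, now gives a step beyond the scatter: nitro in place of methoxy brings a 2.6-fold lower number from compound 2 to compound 3 (0.42 log units; beyond the scatter) and this step is modest, whereas the earlier change from hydrogen to methoxy stayed within the scatter. Nitro in place of hydrogen brings a 1.6-fold lower number from compound 1 to compound 3 (0.21 log units; within the scatter) and this too stays within the scatter, so the only separation shown in this place is between the two substituted compounds, and the unsubstituted compound 1 cannot be told apart from either of them. Nothing measured here offers a reason for the step between methoxy and nitro.

Open, as far as these compounds go, is whether an amine or a carboxylic acid in this same place would read with nitro, with methoxy or outside the span of the three numbers. Also open, from the compounds shown here alone, is whether the step from methoxy to nitro keeps its direction and size when the two trifluoromethyl groups shared by all three compounds give way to chlorine or a nitrile.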